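Ester series: piperidinylmethyl in place of the phenol hydroxy

The compounds below may be only part of what the source reports. "The series", "measured", "known", "first", "only" and "open" are said of these compounds alone.

Three esters have been measured in an assay on COS-7 cells for inhibition of patatin-like phospholipase domain-containing protein 2 (Mus musculus), tested at 200 uM; on this read-out higher numbers stand for more inhibition at the one concentration tested (going by the name of the read-out) and lower numbers for less inhibition. Compound 1 `CCOC(=O)c1cccc(-c2ccc(OCC)cc2)n1` gives 79%, compound 2 `CCOC(=O)c1ccc(-c2ccc(OCC)cc2)s1` gives 81%, and compound 3 `CCOC(=O)c1cccc(-c2ccc(O)cc2)c1` gives 77%. All three numbers lie within the usual scatter of one another, so compound 3 stands level with compounds 1 and 2 and nothing separates them on this read-out. Compound 4 `CCOC(=O)c1cccc(-c2ccc(CN3CCCCC3)cc2)c1` is the next candidate. Against compound 3 the change is (piperidin-1-yl)methyl in place of hydroxy on an aromatic carbon. Among the compounds with values here, no step between measured compounds touches this group, so its weight cannot be read from the series. The step of a number 2 percentage points lower from compound 3 to compound 4 (within the scatter) is expected to stay within the scatter, in no particular direction. For compound 4 the estimate in this assay is 75%, with a range from 50% to 92%.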

Compound 4, a percentage reported as inhibition, at one concentration (the size of the read-out at that concentration, not a potency): 68%
The estimate for compound 4 lay 7 percentage points above the measured number, within the range that was stated.
By their numbers in this assay, from the lowest: compounds 4, 3, 1 and 2 (each within the scatter of the next, the first and the last beyond it).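

Putting (piperidin-1-yl)methyl in place of hydroxy on the aromatic carbon para to a large group gives a number 9 percentage points lower from compound 3 to compound 4 (within the scatter) in this assay. This position therefore accepts a much larger group carrying a six-membered non-aromatic ring, with no hydrogen-bond donor, without a step beyond the scatter. No measurement on hand offers any explanation for this result.

On these data alone, whether a morpholin-4-ylmethyl group, a carboxylic acid or a longer chain at this position would separate from compound 3 beyond the scatter remains open. Potency also remains open, since each compound has a number at only one concentration.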